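Cyclopropyl on the ring amine nitrogen: expected exposure

The compounds below may be only part of what the source reports. "The series", "measured", "known", "first", "only" and "open" are said of these compounds alone.

Going by the values given here, in an ADME assay on the whole organism (plasma, strain Sprague-Dawley) for pharmacokinetics, with Rattus norvegicus as the target, read by LC-MS, at a dose of 10 mg/kg by the oral route (a lower number here means less compound in the circulation, a higher number more compound in the circulation at the dose given), compound 1 `CC(C)(C)c1cc(NC(=O)Nc2ccc(NC(=O)c3ccc(OC4CCN(C(C)(C)C)CC4)cn3)cc2)no1` gives 2670 ng.h/mL and compound 2 `CC(C)(C)c1cc(NC(=O)Nc2ccc(NC(=O)c3ccc(OC4CCNCC4)cn3)cc2)no1` gives 766 ng.h/mL, so compound 2 holds the lower of the two numbers so far. Compound 3 `CC(C)(C)c1cc(NC(=O)Nc2ccc(NC(=O)c3ccc(OC4CCN(C5CC5)CC4)cn3)cc2)no1` carries cyclopropyl in place of hydrogen on an amine nitrogen in a ring. Among the compounds with values here, one measured step bears on this place: a 3.5-fold lower number from compound 1 to compound 2 (0.54 log units; beyond the scatter), a modest step beyond the scatter, with hydrogen in place of tert-butyl. Read in reverse, that step points to a higher number in this assay when a group replaces hydrogen on this nitrogen. One pair is thin support, and cyclopropyl is not tert-butyl, so an upward step of similar or smaller size is expected. The estimated change is a 2.2-fold higher number from compound 2 to compound 3 (0.35 log units; beyond the scatter). Compound 3 is expected at 1700 ng.h/mL, with an estimated range from 750 ng.h/mL to 3800 ng.h/mL.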

Compound 3, area under the concentration-time curve: 4930 ng.h/mL
Beside the measured number, compound 3's estimate is 2.9-fold (0.46 log units) below it; measured number above the stated range.
By their numbers in this assay, from the lowest: compound 2; then compounds 1 and 3 (each within the scatter of the next).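

In this assay a second carbon group on this ring nitrogen moves the number the same way as tert-butyl, now with a larger step for cyclopropyl in place of hydrogen (a 6.4-fold higher number from compound 2 to compound 3 (0.81 log units; beyond the scatter)), so compound 2, with the free amine, stands apart from both substituted compounds. The exchange of tert-butyl for cyclopropyl stays inside the usual spread (a 1.8-fold higher number from compound 1 to compound 3 (0.27 log units; within the scatter)), so these two groups are not told apart at this position. Nothing at hand gives a cause for either step.

On these data alone, whether methyl or acetyl on the same nitrogen would sit with compound 1 and compound 3 or with compound 2 remains open. Also open, as far as these compounds go, is whether a longer chain, or a hydroxyethyl group, on this nitrogen would keep the number at that level.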